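This account rests on a few compounds, and the source may have more. Where it says the series, first, only, none or still open, it means among the compounds named here.

In a functional assay on MT4 cells (Homo sapiens) for cytotoxicity (on this read-out lower numbers stand for stronger inhibition and higher numbers for weaker inhibition), compound 1 `N#Cc1c(N)cccc1S(=O)(=O)c1ccccc1` gives > 5000 nM, which is a limit and not a number. For the measured compounds named here, compound 1 therefore has no exact position on this scale, and the two related compounds measured so far have none either.

Compound 4 `N#Cc1c(N)cccc1S(=O)(=O)c1ccccc1Br` is compound 1 with a single change: bromo in place of hydrogen on an aromatic carbon. In words, this is bromo in place of hydrogen on an aromatic carbon, ortho to a large group.

Going by the values given here, two measured steps bear on this change, since each also starts from compound 1 and swaps one hydrogen for a different substituent. Compound 3 `N#Cc1c(N)cccc1S(=O)(=O)c1ccc(Cl)cc1`, which carries chloro, gives > 5000 nM, again a limit. Compound 2 `COc1ccc(S(=O)(=O)c2cccc(N)c2C#N)cc1`, which carries methoxy, gives > 200000 nM, also a limit. Neither step has a size that can be read: the data show a step that the two limits leave unreadable from compound 1 to compound 3, and a step that the two limits leave unreadable from compound 1 to compound 2.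

Compound 2 stands at > 200000 nM, so a move toward higher numbers in this assay, meaning weaker inhibition, is the expected direction. The estimated step is a step that the limit leaves unreadable from compound 1 to compound 4. The result may well arrive as a limit again. For compound 4 the expected value is 50000 nM, with an estimated range from 8000 nM to 200000 nM.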

Compound 4, half-maximal inhibitory concentration: 40000 nM
Beside the measured number, compound 4's estimate is 1.3-fold (0.10 log units) above it, and the stated range covers the measured number.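

Compound 4 now has an exact value, but compound 1 has only a limit, and so no new step can be read between compound 1 and compound 4. The compounds shown leave open how far bromo in place of hydrogen moves the result in this assay, and whether any of the substituents shown moves it at all.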